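A Styryl Arm Gives Way to a Dimethoxyphenyl Arm

The source may report more compounds than this note shows. Statements on the series, on what has been measured and on what is new or still open speak of the compounds shown alone.

The three measured compounds, each with its result:
compound 1, `Cc1cc(O)c(C2=NN(c3ccc(S(N)(=O)=O)cc3)C(c3ccccc3O)C2)cc1Cl`, gives 1810 nM;
compound 2, `Cc1cc(O)c(C2=NN(c3ccc(S(N)(=O)=O)cc3)C(c3ccccc3Cl)C2)cc1Cl`, gives 1890 nM;
compound 3, `Cc1cc(O)c(C2=NN(c3ccc(S(N)(=O)=O)cc3)C(/C=C/c3ccccc3)C2)cc1Cl`, gives 11500 nM.

These numbers come from a functional assay on OVCAR-3 cells (Homo sapiens) for antiproliferative activity, with a stated time of 48 h; on this read-out higher numbers stand for weaker inhibition of growth and lower numbers for stronger inhibition of growth. Compound 3 stands highest of the three, the weakest inhibitor of growth, with compound 2 nearest and compound 1 furthest, both steps beyond the scatter. Compound 4, `COc1ccc(C2CC(c3cc(Cl)c(C)cc3O)=NN2c2ccc(S(N)(=O)=O)cc2)cc1OC`, has not yet been measured. It differs from compound 3 in one place: 3,4-dimethoxyphenyl in place of 2-phenylethenyl on a saturated ring carbon.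

For the measured compounds named here, two measured steps bear on this change, both running the other way, from an aromatic ring attached directly to the saturated ring carbon to the 2-phenylethenyl group: a 6.4-fold higher number from compound 1 to compound 3 (0.80 log units; beyond the scatter) and a 6.1-fold higher number from compound 2 to compound 3 (0.78 log units; beyond the scatter). Going by the values given here, compound 4 restores a directly attached aromatic ring, although no measured compound carries the 3,4-dimethoxyphenyl pattern, so the size of its effect rests on a reading of the two steps above rather than on a direct precedent. The expectation for compound 4 is therefore a drop of about the size of those steps, toward stronger inhibition, that is a 4.6-fold lower number from compound 3 to compound 4 (0.66 log units; beyond the scatter). The estimate for compound 4 in this assay is 2500 nM, with a range from 900 nM to 7000 nM.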

Compound 4, concentration for 50% growth inhibition: 3370 nM
For compound 4 the middle estimate is 1.3-fold (0.13 log units) below the measured one, and the stated range covers the measured number.
By their numbers in this assay, from the lowest: compounds 1, 2 and 4 (each within the scatter of the next); then compound 3.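

In this assay, the 3,4-dimethoxyphenyl group on the saturated ring carbon gives a lower number than the 2-phenylethenyl group (a 3.4-fold lower number from compound 3 to compound 4 (0.53 log units; beyond the scatter)), so the gap that the 2-hydroxyphenyl and 2-chlorophenyl groups opened against compound 3 also holds for a third directly attached aromatic ring, one bearing two methoxy groups. Set against those two rings, the new group stays within the scatter (a 1.8-fold higher number from compound 2 to compound 4 (0.25 log units; within the scatter) and a 1.9-fold higher number from compound 1 to compound 4 (0.27 log units; within the scatter)), so compounds 1, 2 and 4 cannot be told apart here, and among these three compounds this carbon accepts hydroxy, chloro or a pair of methoxy groups on the ring without a readable change. Nothing available accounts for why the 2-phenylethenyl group stands apart from these three aromatic rings.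

The compounds shown leave open whether that gap depends on the double bond itself, a question that a 2-phenylethyl chain or a benzyl group on the same carbon would address. They also leave open whether a phenyl ring carrying an amine or a carboxylic acid would stay level with compounds 1, 2 and 4.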